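The source may report more compounds than this note shows. Statements on the series, on what has been measured and on what is new or still open speak of the compounds shown alone.

In a functional assay on MCF7 cells (Homo sapiens) for antiproliferative activity, read by MTT assay, with a stated time of 72 h (on this read-out higher numbers stand for weaker inhibition and lower numbers for stronger inhibition), compound 1 `CC1=CC[C@H]2[C@H](CC[C@]2(C)O)C(C)(C)[C@@H]1CC[C@H]1[C@]2(C)CC[C@H](OCc3ccccc3)C(C)(C)O[C@H]2CC[C@@]1(C)O` gives > 50000 nM, which is a limit of the assay and not a number. Among the compounds with values here, compound 2 `CC1=CC[C@H]2[C@H](CC[C@]2(C)O)C(C)(C)[C@@H]1CC[C@H]1[C@]2(C)CC[C@H](OC(=O)c3ccc(C(F)(F)F)cc3)C(C)(C)O[C@H]2CC[C@@]1(C)O` gives 23400 nM, the only true number so far, so it has no measured neighbour to be ranked against. Within the data shown here, the single measured step, an at least 2.1-fold lower number from compound 1 to compound 2 (0.32 log units; beyond the scatter), came from placing (4-(trifluoromethyl)phenyl)carbonyl in place of benzyl on an oxygen, and it rests on (the limit of > 50000 nM in this assay, at which 1 of the 2 values shown sits). Compound 3 `COc1ccc(C(=O)O[C@H]2CC[C@]3(C)[C@H](CC[C@@](C)(O)[C@H]3CC[C@@H]3C(C)=CC[C@H]4[C@H](CC[C@]4(C)O)C3(C)C)OC2(C)C)cc1` keeps the rest of compound 2 and carries methoxy in place of trifluoromethyl on an aromatic carbon, para to a large group (methoxy in place of trifluoromethyl on an aromatic carbon). Among the measured compounds shown here, no measured step tests this exchange, so the earlier step offers only weak guidance, and no clear direction is expected. The expected change is small, a 1.1-fold higher number from compound 2 to compound 3 (0.03 log units; within the scatter), and is not expected to go beyond the scatter. For compound 3 the estimate is 25000 nM, with an expected range of 11000 nM to 50000 nM.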

Compound 3, half-maximal inhibitory concentration: 41700 nM
Compound 3: the middle estimate sits 1.7-fold (0.22 log units) below what was measured; measured number inside the range.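

In this assay, the exchange of trifluoromethyl for methoxy on the aromatic carbon para to a large group gives a 1.8-fold higher number from compound 2 to compound 3 (0.25 log units; within the scatter), so the compounds shown do not separate these two groups at this position. The step from benzyl to (4-methoxyphenyl)carbonyl on the same oxygen gives an at least 1.1-fold lower number from compound 1 to compound 3 (0.07 log units; that floor lies within the scatter), so unlike the earlier step to (4-(trifluoromethyl)phenyl)carbonyl, it does not clearly pass the scatter. Compound 1 stands at a limit of the assay and not at a number, so this step gives only a floor: the limit of > 50000 nM in this assay, at which 1 of the 3 values shown sits.

On these data alone, it remains open whether an amine or a carboxylic acid on this same aromatic carbon would move the number beyond the scatter. As far as these compounds go, it is also open whether a simple acetyl group on the oxygen would keep the activity of compound 2.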